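Dropping the ring acetoxy: compound 3 to compound 4

This account rests on a few compounds, and the source may have more. Where it says the series, first, only, none or still open, it means among the compounds named here.

Among the measured compounds shown here, in a functional assay (aorta) for inhibition, with Rattus norvegicus as the target (a higher number here means a weaker inhibitor, a lower number a stronger inhibitor), compound 3 `CC(=O)O[C@H]1[C@H](/N=C(\NC#N)Nc2ccccc2)c2cc(C#N)ccc2OC1(C)C` gives 2600 nM, the second highest of the three numbers so far. Compound 1 `CC1(C)Oc2ccc(C#N)cc2[C@@H](/N=C(\NC#N)Nc2ccccc2)[C@@H]1O` gives 1400 nM, and the step of a 1.9-fold higher number from compound 1 to compound 3 (0.27 log units; within the scatter) stays within the scatter. Compound 2 `CC1(C)Oc2ccc(C#N)cc2[C@@H](/N=C(\NC#N)Nc2ccccc2)[C@H]1O` gives 17000 nM; the step of a 12-fold higher number from compound 1 to compound 2 (1.08 log units; beyond the scatter) is large because of the fact that compounds 1 and 2 differ only in the configuration as drawn. Compound 4 `CC1(C)C[C@H](/N=C(\NC#N)Nc2ccccc2)c2cc(C#N)ccc2O1` differs from compound 3 by hydrogen in place of acetoxy on a saturated ring carbon. The step from compound 1 to compound 3 bears most directly on this change and was small; the configuration step shows that the saturated ring carbon matters, but compound 4 carries no group there at all. The expected step is modest, a 1.3-fold higher number from compound 3 to compound 4 (0.13 log units; within the scatter). Compound 4 is estimated at 3500 nM in this assay, with a range of 1200 nM to 12000 nM.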

Compound 4, half-maximal inhibitory concentration: 14000 nM
Compound 4: the middle estimate sits 4.0-fold (0.60 log units) below what was measured; measured number above the stated range.
By their numbers in this assay, from the lowest: compounds 1 and 3 (each within the scatter of the next); then compounds 4 and 2 (each within the scatter of the next).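

Losing the oxygen group on this saturated ring carbon is not neutral: hydrogen for acetoxy gives a 5.4-fold higher number from compound 3 to compound 4 (0.73 log units; beyond the scatter), and hydrogen for hydroxy gives a 10-fold higher number from compound 1 to compound 4 (1.00 log units; beyond the scatter). Hydrogen for the hydroxy of the other configuration, however, gives a 1.2-fold lower number from compound 2 to compound 4 (0.08 log units; within the scatter). An oxygen group here therefore goes with a lower number only as drawn in compound 1 and compound 3, and configuration alone separates the two hydroxy compounds: the fact that compounds 1 and 2 differ only in the configuration as drawn.

Open, as far as these compounds go, is whether an amine or a methoxy group on this carbon keeps the lower number, and whether acetoxy in the configuration of compound 2 tracks its hydroxy.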